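A few compounds are considered here, and "the series" means these few. Any claim that something is new, unique, unknown or untested is made for them only; others in the source may bear on it.

Measured in an ADME assay on microsomes from liver (Rattus norvegicus) for metabolic stability, read by LC-MS, with a stated time of 10 min, tested at 0.5 uM; a lower number here means that less of the compound is left, a higher number that more of the compound is left:
- compound 1 `c1ccc2c(c1)CN[C@@H](CN(CC1CCNCC1)[C@H]1CCCc3cccnc31)C2`: 65%
- compound 2 `CN1CCN(CCCN(C[C@H]2Cc3ccccc3CN2)[C@H]2CCCc3cccnc32)CC1`: 10%

Compound 2, at 10%, is the lowest of the two numbers in this assay. Compound 3 `c1ccc2c(c1)CN[C@@H](CN(CCCCN1CCNCC1)[C@H]1CCCc3cccnc31)C2` differs from it by (piperazin-1-yl)methyl in place of 4-methylpiperazin-1-yl on a saturated chain carbon, three bonds along the chain from an amine nitrogen: (piperazin-1-yl)methyl in place of 4-methylpiperazin-1-yl, on a saturated chain carbon, three bonds along the chain from an amine nitrogen. Within the data shown here, only one measured step bears on this, the large a number 55 percentage points lower from compound 1 to compound 2 (beyond the scatter), and it concerns a different replacement, so it offers indirect guidance. A moderate rise is expected, namely a number 18 percentage points higher from compound 2 to compound 3 (beyond the scatter), though its size is uncertain. For compound 3 the estimated value is 28%, with an expected range of 8% to 58%.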

Compound 3, percent of the compound remaining: 15%
For compound 3 the middle estimate is 13 percentage points above the measured one, within the range that was stated.
By their numbers in this assay, from the lowest: compounds 2 and 3 (each within the scatter of the next); then compound 1.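

In this assay, the exchange of 4-methylpiperazin-1-yl for (piperazin-1-yl)methyl at this chain position, which adds one hydrogen-bond donor and keeps the heavy-atom count, gives a number 5 percentage points higher from compound 2 to compound 3 (within the scatter) and so does not separate the two compounds. With a number 50 percentage points lower from compound 1 to compound 3 (beyond the scatter) as well, the low reading of compound 2 is no longer a single case: both piperazine-bearing chains stand well under the piperidin-4-yl compound. Nothing available explains either step.

Open, from the compounds shown here alone, is whether a morpholin-4-yl group at the end of the same chain would read with the piperazines or nearer compound 1. Also open, going by these compounds, is whether a longer chain ending in piperidin-4-yl would keep the value of compound 1.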